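A few compounds are considered here, and "the series" means these few. Any claim that something is new, unique, unknown or untested is made for them only; others in the source may bear on it.

Measured in a functional assay on MCF7 cells (Homo sapiens) for antiproliferative activity, read by MTT assay, with a stated time of 72 h; on this read-out higher numbers stand for weaker inhibition and lower numbers for stronger inhibition:
- Compound 1 `CN(c1ccccc1Cl)S(=O)(=O)C1CC2OC1C(c1ccc(NC(=O)CCCCCCC(=O)O)cc1)=C2c1ccc(O)cc1`: 12800 nM
- Compound 2 `CCN(c1ccc(O)cc1)S(=O)(=O)C1CC2OC1C(c1ccc(NC(=O)CCCCCCC(=O)O)cc1)=C2c1ccc(O)cc1`: 46600 nM

Compound 2, at 46600 nM, has the higher of the two numbers, so it is the weaker inhibitor. Compound 3 `CCN(c1ccccc1Cl)S(=O)(=O)C1CC2OC1C(c1ccc(NC(=O)CCCCCCC(=O)O)cc1)=C2c1ccc(O)cc1` differs from it in one place: 2-chlorophenyl in place of 4-hydroxyphenyl on a sulfonamide nitrogen, with 2-chlorophenyl in place of 4-hydroxyphenyl on a sulfonamide nitrogen. Within the data shown here, the only measured step that bears on this is a 3.6-fold higher number from compound 1 to compound 2 (0.56 log units; beyond the scatter). That modest step brought in 4-hydroxyphenyl, but it also exchanged methyl for ethyl. Undoing most of it should lower the number in this assay by a similar size, an expected 3.1-fold lower number from compound 2 to compound 3 (0.49 log units; beyond the scatter). Compound 3 is estimated at 15000 nM, with an expected range of 6500 nM to 35000 nM.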

Compound 3, half-maximal inhibitory concentration: 33300 nM
Beside the measured number, compound 3's estimate is 2.2-fold (0.35 log units) below it; the range from low to high includes it.
By their numbers in this assay, from the lowest: compound 1; then compounds 3 and 2 (each within the scatter of the next).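

In this assay replacing 4-hydroxyphenyl with 2-chlorophenyl while ethyl stays on the sulfonamide nitrogen gives a 1.4-fold lower number from compound 2 to compound 3 (0.15 log units; within the scatter) and so these two rings cannot be told apart here. Going from methyl to ethyl on that nitrogen with 2-chlorophenyl kept gives a 2.6-fold higher number from compound 1 to compound 3 (0.42 log units; beyond the scatter) and so the earlier gap, where both parts changed at once, now traces mainly to this one change. Nothing available explains this difference.

On these data alone, whether a longer chain such as propyl on that nitrogen would push the number further remains open. So does how a ring carrying an amine would compare.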